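Removing the Nitrile from the Phenyl Ring of Compound 3

The compounds below may be only part of what the source reports. "The series", "measured", "known", "first", "only" and "open" are said of these compounds alone.

Compound 3 `COc1ccc(/C=C\C(=O)O)c(OCc2cn(-c3cccc(C#N)c3)nn2)c1CC=C(C)C` is one of three close relatives built on a shared core. In a functional assay on PC-3 cells (Homo sapiens) for cytotoxicity, read by MTT assay, with a stated time of 24 h (a lower number here means a stronger inhibitor, a higher number a weaker inhibitor), compound 3 gives 45500 nM, the higher of the two numbers available. Its nearest neighbour, compound 2 `COc1ccc(/C=C\C(=O)O)c(OCc2cn(-c3ccccc3F)nn2)c1CC=C(C)C`, gives 24200 nM in this assay. The step of a 1.9-fold higher number from compound 2 to compound 3 (0.27 log units; within the scatter) comes from exchanging the group on the aromatic nitrogen and stays within the scatter. Compound 1 `COc1ccccc1-n1cc(COc2c(/C=C\C(=O)O)ccc(OC)c2CC=C(C)C)nn1` also differs only in that group, but in this assay compound 1 gives "not determined" (no result reported), so no result was reported for it.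

Compound 4 `COc1ccc(/C=C\C(=O)O)c(OCc2cn(-c3ccccc3)nn2)c1CC=C(C)C` differs from compound 3 by hydrogen in place of cyano on an aromatic carbon. Among the compounds with values here, the only measured step that bears on this change, a 1.9-fold higher number from compound 2 to compound 3 (0.27 log units; within the scatter), likewise altered the group on the aromatic nitrogen and did not move beyond the scatter. Compound 4 is therefore expected to show no step beyond the scatter, a 1.3-fold lower number from compound 3 to compound 4 (0.11 log units; within the scatter). For compound 4 the estimate in this assay is 35000 nM, with a range from 12000 nM to 100000 nM.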

Compound 4, half-maximal inhibitory concentration: 35000 nM
Beside the measured number, compound 4's estimate shows no gap at the digits printed; the range from low to high includes it.
By their numbers in this assay, from the lowest: compounds 2, 4 and 3 (each within the scatter of the next).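

Compound 4 carries a plain phenyl on the aromatic nitrogen, which gives the series the unsubstituted comparison it lacked. In this assay, hydrogen in place of cyano gives a small step (a 1.3-fold lower number from compound 3 to compound 4 (0.11 log units; within the scatter)), and hydrogen in place of fluoro gives another (a 1.4-fold higher number from compound 2 to compound 4 (0.16 log units; within the scatter)), so neither the nitrile of compound 3 nor the fluoro group of compound 2 separates from bare phenyl in this assay. Nothing available explains why these numbers lie so close together.

Steps involving compound 1 cannot be read, so all that can be compared here is hydrogen, fluoro and cyano on this phenyl ring. As far as these compounds go, whether an amine or a longer chain on the ring would give a step beyond the scatter stays open, as does the effect of any change to the shared core.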